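Liver microsome stability: swapping the benzothiazole arm in compound 2

The compounds below may be only part of what the source reports. "The series", "measured", "known", "first", "only" and "open" are said of these compounds alone.

Measured compounds in an ADME assay on microsomes from liver (Mus musculus) for metabolic stability, read by LC-MS, with a stated time of 10 min, tested at 0.5 uM; on this read-out higher numbers stand for a more stable compound and lower numbers for a less stable compound:
compound 1 `CN1CCN(CCCN(C[C@H]2Cc3ccccc3CN2)[C@H]2CCCc3cccnc32)CC1` gives 53%
compound 2 `c1cnc2c(c1)CCC[C@@H]2N(CCCN1CCNCC1)Cc1nc2ccccc2s1` gives 45%
compound 3 `CC(C)N1CCN(CCCN(C[C@H]2Cc3ccccc3CN2)[C@H]2CCCc3cccnc32)CC1` gives 58%

Compound 2 holds the smallest of the three numbers. Compound 1 stands within the scatter of compound 2, and compound 3 stands beyond it. Going by the values given here, the one step measured within the set, a number 5 percentage points higher from compound 1 to compound 3 (within the scatter), concerns the amine nitrogen in a ring and does not touch the arm that changes here.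

Compound 4 `c1cnc2c(c1)CN[C@H](CN(CCCN1CCNCC1)[C@H]1CCCc3cccnc31)C2` differs from compound 2 at one place: a group of 10 heavy atoms (8 carbon, 2 nitrogen; one six-membered non-aromatic ring with 1 hetero atom, one six-membered aromatic ring with 1 hetero atom) in place of a group of 9 heavy atoms (7 carbon, 1 nitrogen, 1 sulfur; one five-membered aromatic ring with 2 hetero atoms, one six-membered aromatic ring of carbon only), on a saturated chain carbon bound to an amine nitrogen. Among the compounds with values here, no measured step covers this exchange, so no measured size can be carried over. Compound 1, which carries a related group of two fused rings on the same chain carbon, gives 53%, and compound 3, which carries the same group, gives 58%; their numbers and that of compound 2 all sit in a narrow band. On that basis compound 4 is expected to give 50%, with a range from 30% to 70%. The expected step of a number 5 percentage points higher from compound 2 to compound 4 (within the scatter) is small, and no change beyond the scatter is anticipated.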

Compound 4, percent of the compound remaining: 63%
Compound 4: the middle estimate sits 13 percentage points below what was measured; the measured number falls inside the stated range.
By their numbers in this assay, from the lowest: compounds 2, 1, 3 and 4 (each within the scatter of the next, the first and the last beyond it).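

In this assay, going by these compounds alone, the arm on a saturated chain carbon bound to an amine nitrogen is the first place where a single exchange moves the number beyond the scatter (a number 18 percentage points higher from compound 2 to compound 4 (beyond the scatter)), whereas the earlier step on the ring amine nitrogen stayed within it. The exchange changes several counted features at once: a six-membered non-aromatic ring replaces a five-membered aromatic ring, and the entering group brings 1 hydrogen-bond donor and 1 defined stereocentre, so this one step cannot assign the gain to any of them. No measurement on hand gives a reason for the step.

Going by these compounds, it remains open which feature of the entering group carries the step. A phenyl or a pyridin-2-yl group on the same chain carbon, or a methyl on the ring nitrogen of the entering group, would help to separate these features.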